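This account rests on a few compounds, and the source may have more. Where it says the series, first, only, none or still open, it means among the compounds named here.

Measured compounds:
compound 1 `Oc1cccc(-c2cc(-c3ccc(F)cc3)cc(-c3ccccc3O)n2)c1` — > 50000 nM
compound 2 `Oc1cccc(-c2cc(-c3cccc(F)c3)cc(-c3cccc(O)c3)n2)c1` — 21300 nM

In a functional assay on T47D cells (Homo sapiens) for inhibition (on this read-out higher numbers stand for weaker inhibition and lower numbers for stronger inhibition), compound 1 gives only > 50000 nM, which is a limit of the assay and not a number; this is the limit of > 50000 nM in this assay, at which 1 of the 2 values shown sits. Compound 2 gives 21300 nM in this assay, the only number shown.

Compound 3 `Oc1cccc(-c2cc(-c3ccc(F)cc3)cc(-c3cccc(O)c3)n2)c1` has the same atoms as compound 2 joined differently: 4-fluorophenyl in place of 3-fluorophenyl on an aromatic carbon, the 4-fluorophenyl entering on an aromatic carbon opposite the ring nitrogen. Among the compounds with values here, no step between measured compounds is available to gauge such a change, so the author expects in this assay either no shift beyond the scatter or a modest drift toward weaker inhibition.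

Compound 3 is therefore estimated at 30000 nM, within 10000 nM to 60000 nM, an expected step of a 1.4-fold higher number from compound 2 to compound 3 (0.15 log units; within the scatter).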

Compound 3, half-maximal inhibitory concentration: 6870 nM
For compound 3 the middle estimate is 4.4-fold (0.64 log units) above the measured one; measured number below the stated range.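

In this assay, the position opposite the ring nitrogen now has its first measured step, and it shows that where the fluorine sits on the phenyl group matters even though the atoms stay the same: 4-fluorophenyl in place of 3-fluorophenyl gives a 3.1-fold lower number from compound 2 to compound 3 (0.49 log units; beyond the scatter). A second step shows that the hydroxyphenyl group matters too: 3-hydroxyphenyl in place of 2-hydroxyphenyl gives an at least 7.2-fold lower number from compound 1 to compound 3 (0.86 log units; beyond the scatter). Compound 1 stands at a limit and not at a number, so the true size of that step stays unknown: the limit of > 50000 nM in this assay, at which 1 of the 3 values shown sits.

The compounds shown leave open whether an unsubstituted phenyl or a methoxyphenyl group opposite the ring nitrogen would continue this trend. They also leave open how an amine or a carboxylic acid would compare with the hydroxyl groups of compound 3.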